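This account rests on a few compounds, and the source may have more. Where it says the series, first, only, none or still open, it means among the compounds named here.

Values in a functional assay on MCF7 cells (Homo sapiens) for cytotoxicity, read by MTT assay, with a stated time of 72 h (a higher number here means a weaker inhibitor, a lower number a stronger inhibitor), for the measured compounds are as follows.

Compound 1 `O=C(N/N=C/c1ccc([N+](=O)[O-])cc1)Nc1cc2c(Nc3ccc(F)c(Cl)c3)ncnc2cc1O[C@H]1CCOC1` gives "not active" (no number reported) 
Compound 2 `COc1ccc(/C=N/NC(=O)Nc2cc3c(Nc4ccc(F)c(Cl)c4)ncnc3cc2O[C@H]2CCOC2)cc1` gives 27300 nM 
Compound 3 `O=C(N/N=C/c1ccc(O)cc1O)Nc1cc2c(Nc3ccc(F)c(Cl)c3)ncnc2cc1O[C@H]1CCOC1` gives 5350 nM 

Compound 4 `COc1ccc(/C=N/NC(=O)Nc2cc3c(Nc4ccc(F)c(Cl)c4)ncnc3cc2OC)cc1` has yet to be measured. Compound 2, at 27300 nM in this assay, holds the higher of the two numbers available, while compound 1 offers no number to compare. The path to compound 4 is a single change (methyl in place of oxolan-3-yl on an oxygen on an aromatic ring) that puts methyl in place of oxolan-3-yl on an oxygen on an aromatic ring.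

Among the measured compounds shown here, the only measured step (a 5.1-fold lower number from compound 2 to compound 3 (0.71 log units; beyond the scatter)) is modest, but it exchanges 4-methoxyphenyl for 2,4-dihydroxyphenyl and leaves the oxolan-3-yl group untouched. For the measured compounds named here, no measured pair alters that group, so the data indicate neither the size nor the direction of this change, and no step beyond the scatter is expected in this assay on present evidence. The estimate is a small expected change (a 1.2-fold lower number from compound 2 to compound 4 (0.09 log units; within the scatter)) with wide uncertainty. For compound 4 the expected value is 22000 nM with an estimated range from 7000 nM to 70000 nM in this assay.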

Compound 4, half-maximal inhibitory concentration: 8140 nM
Estimate against measurement, compound 4: 2.7-fold (0.43 log units) above, within the range that was stated.
By their numbers in this assay, from the lowest: compounds 3 and 4 (each within the scatter of the next); then compound 2.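

Methyl in place of oxolan-3-yl on an oxygen on an aromatic ring gives a 3.4-fold lower number from compound 2 to compound 4 (0.53 log units; beyond the scatter) in this assay and so shows that this position also responds, which the earlier compounds could not show, as all of them carry oxolan-3-yl. The step is modest, but it is beyond the scatter and goes to the lower number with the smaller group. In this one pair, then, neither the five-membered ring nor the defined stereocentre is needed to reach the lower number.

Open, going by these compounds, is whether the same change holds alongside the 2,4-dihydroxyphenyl group of compound 3, and how an ethyl group or a longer chain ending in an amine would behave on this oxygen. Nothing measured here explains why the number falls with methyl.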